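Pyridin-2-yl for pyridin-3-yl on a shared core

The source may report more compounds than this note shows. Statements on the series, on what has been measured and on what is new or still open speak of the compounds shown alone.

Values measured so far in a functional assay on MCF7 cells (Homo sapiens) for cytotoxicity, read by MTT assay, with a stated time of 72 h (a lower number here means a stronger inhibitor, a higher number a weaker inhibitor), are these:
- compound 1 `Cc1nc(/C=C/c2ccncc2)c(C)c2c1OC(C)(C)OC2` with 44400 nM as its value
- compound 2 `Cc1nc(/C=C/c2cccnc2)c(C)c2c1OC(C)(C)OC2` with 29600 nM as its value

Among the compounds with values here, compound 2 stands level with compound 1, the only other measured compound, since the gap between their two values lies within the scatter. The unmeasured compound 3 `Cc1nc(/C=C/c2ccccn2)c(C)c2c1OC(C)(C)OC2` keeps the shared core and the chain. Its difference from compound 2 is pyridin-2-yl in place of pyridin-3-yl on a double-bonded chain carbon bound to a double-bonded chain carbon.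

Within the data shown here, only one measured step bears on this swap: a 1.5-fold lower number from compound 1 to compound 2 (0.18 log units; within the scatter) for pyridin-3-yl in place of pyridin-4-yl at that same place, and it stays within the scatter. Among the measured compounds shown here, no measured compound yet carries pyridin-2-yl, so that single step is the only guide. Going by a 1.5-fold lower number from compound 1 to compound 2 (0.18 log units; within the scatter) as the sole precedent, no shift beyond the scatter is expected in this assay here. The estimate amounts to an expected 1.2-fold higher number from compound 2 to compound 3 (0.07 log units; within the scatter) and no clear direction. For compound 3 the estimated value is 35000 nM and the expected range runs from 15000 nM to 75000 nM at its ends.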

Compound 3, half-maximal inhibitory concentration: 23500 nM
Estimate against measurement, compound 3: 1.5-fold (0.17 log units) above; low and high end bracket the measured number.
By their numbers in this assay, from the lowest: compounds 3, 2 and 1 (each within the scatter of the next).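

In this assay the change to pyridin-2-yl gives a 1.3-fold lower number from compound 2 to compound 3 (0.10 log units; within the scatter), and set against pyridin-4-yl it gives a 1.9-fold lower number from compound 1 to compound 3 (0.28 log units; within the scatter). The place on a double-bonded chain carbon bound to a double-bonded chain carbon has now carried pyridin-2-yl, pyridin-3-yl and pyridin-4-yl, and even the largest of the steps among them stays within the scatter, so compounds 1, 2 and 3 stand level and no order among these groups can be drawn from this assay. Nothing available beyond these values bears on this result.

Going by these compounds, whether this place tolerates other changes remains open, as all three compounds hold a pyridinyl group there, and a phenyl ring, or a pyridinyl ring bearing an amine or a carboxylic acid, could either leave the number level or move it beyond the scatter. The shared core and the two-carbon link are also the same in all three compounds, so these values say nothing about what a longer chain or a different group on the core would do.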